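Nitro Added to the Benzyl Ring of a Cytotoxic Amidine

The source may report more compounds than this note shows. Statements on the series, on what has been measured and on what is new or still open speak of the compounds shown alone.

Compound 1 `N=C(NCc1ccc(O)cc1)[C@@H]1CCC(=O)N1Cc1ccccc1` is the reference point of this small comparison. Among the measured compounds shown here, in a functional assay on SH-SY5Y cells (Homo sapiens) for cytotoxicity, read by MTT assay, with stated times of 8 h, 30 min and 12 h, tested at 5 uM (a higher number here means a stronger effect of the compound at the concentration tested, a lower number a weaker effect), compound 1 gives 37.6%, the highest of the two numbers available; its only neighbour, compound 2 `COc1ccc(CNC(=N)[C@@H]2CCC(=O)N2Cc2ccccc2)cc1`, gives 19.5%. For the measured compounds named here, the one measured step, a number 18.1 percentage points lower from compound 1 to compound 2 (beyond the scatter), is beyond the scatter and comes from a methyl in place of hydrogen on an oxygen on an aromatic ring.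

Compound 3 `N=C(NCc1ccc(O)cc1)[C@@H]1CCC(=O)N1Cc1ccccc1[N+](=O)[O-]` has not yet been measured. It differs from compound 1 by nitro in place of hydrogen on an aromatic carbon: nitro in place of hydrogen, placed on an aromatic carbon of a six-membered aromatic ring of carbon only. Going by the values given here, no measured step bears on this change; the step from compound 1 to compound 2 concerns a different ring and a different group, and it says nothing about what a nitro group on the benzyl ring does. The expectation must therefore rest on compound 1 itself, and the step is expected to stay within the scatter, as a number 2.4 percentage points higher from compound 1 to compound 3 (within the scatter) indicates. For compound 3 the estimated value is 40%, with a range from 20% to 60%.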

Compound 3, a percentage reported as activity, at one concentration (the size of the read-out at that concentration, not a potency): 30.4%
Beside the measured number, compound 3's estimate is 9.6 percentage points above it; the measured number falls inside the stated range.
By their numbers in this assay, from the lowest: compound 2; then compounds 3 and 1 (each within the scatter of the next).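

Changing phenyl to 2-nitrophenyl in this assay gives a number 7.2 percentage points lower from compound 1 to compound 3 (within the scatter) and so leaves the read-out indistinguishable from that of compound 1, which shows that this aromatic carbon, ortho to a large group, can carry nitro without a change beyond the scatter at the single concentration tested. Among the compounds shown here, the earlier step, a number 18.1 percentage points lower from compound 1 to compound 2 (beyond the scatter) and placed on the oxygen of the other aromatic ring, could not show this, and it remains the only step here that lies beyond the scatter. No measurement available here gives a reason for the outcome at the nitro position.

From the compounds shown here alone, one nitro compound cannot show whether this tolerance belongs to the position or to nitro alone, so it remains open whether an amine or a carboxylic acid on the same aromatic carbon would also leave the read-out within the scatter of compound 1. Going by these compounds, it is also open whether nitro in this place would have the same small effect in compound 2, where a methyl sits on the oxygen, and whether the comparison would hold at other concentrations.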